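From phenyl to benzyl: a half-life estimate for compound 4

A few compounds are considered here, and "the series" means these few. Any claim that something is new, unique, unknown or untested is made for them only; others in the source may bear on it.

- Compound 1 `CCC(CC)C(/C=C1\OC(=O)NC1=O)c1ccc(-c2ccc3cccc(F)c3c2)[nH]c1=O` gives > 3 h, a limit of the assay and not a number
- Compound 2 `O=C1NC(=O)/C(=C/C(c2ccc(-c3ccc4cccc(F)c4c3)[nH]c2=O)C2CC2)O1` gives 1.98 h
- Compound 3 `O=C1NC(=O)/C(=C/C(c2ccccc2)c2ccc(-c3ccc4cccc(F)c4c3)[nH]c2=O)O1` gives 2.1 h

These values come from an ADME assay on microsomes from liver (Homo sapiens) for metabolic stability; a lower number here means that the compound disappears faster, a higher number that the compound lasts longer. Compound 3 cannot be told apart from its nearest neighbour, with a 1.1-fold higher number from compound 2 to compound 3 (0.03 log units; within the scatter). Compound 4 `O=C1NC(=O)/C(=C/C(Cc2ccccc2)c2ccc(-c3ccc4cccc(F)c4c3)[nH]c2=O)O1` differs from it by one change, benzyl in place of phenyl on a saturated chain carbon bound to an aromatic carbon and a double-bonded chain carbon.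

Three measured steps involve swaps at this carbon. Two start from the limit of compound 1, so they are only floors: an at least 1.5-fold lower number from compound 1 to compound 2 (0.18 log units; that floor lies within the scatter) and an at least 1.4-fold lower number from compound 1 to compound 3 (0.15 log units; that floor lies within the scatter). With a 1.1-fold higher number from compound 2 to compound 3 (0.03 log units; within the scatter) also small, no step beyond the scatter is expected, and the expected step is a 1.1-fold lower number from compound 3 to compound 4 (0.04 log units; within the scatter). For compound 4 the estimated half-life is 1.9 h, with an expected range of 1 h to 3 h.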

Compound 4, half-life in the Homo sapiens assay: 1.3 h
Beside the measured number, compound 4's estimate is 1.5-fold (0.16 log units) above it; low and high end bracket the measured number.
By their numbers in the Homo sapiens assay, from the lowest: compounds 4, 2 and 3 (each within the scatter of the next). At a limit, above all of these: compound 1.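

In the Homo sapiens assay compound 4 gives 1.3 h, and benzyl stays within the scatter of both phenyl and cyclopropyl at this carbon: a 1.6-fold lower number from compound 3 to compound 4 (0.21 log units; within the scatter), and a 1.5-fold lower number from compound 2 to compound 4 (0.18 log units; within the scatter). Compound 1 holds a limit there, not a number, and its step to benzyl, an at least 2.3-fold lower number from compound 1 to compound 4 (0.36 log units; beyond the scatter), is the only one of these three beyond the scatter. The new finding lies in a physicochemical assay for solubility, measured as kinetic solubility, at pH 2 (on this read-out higher numbers stand for higher solubility and lower numbers for lower solubility), where compound 3 gives 15400 nM and compound 4 gives 900 nM, so that the same swap gives a 17-fold lower number from compound 3 to compound 4 (1.23 log units; beyond the scatter).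

Going by these compounds, whether an amine or a carboxylic acid on this carbon would keep both the half-life and the solubility remains open.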